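The source may report more compounds than this note shows. Statements on the series, on what has been measured and on what is new or still open speak of the compounds shown alone.

Measured so far in a functional assay on SGC-7901 cells (Homo sapiens) for inhibition, read by MTT assay, with a stated time of 24 h; on this read-out higher numbers stand for weaker inhibition and lower numbers for stronger inhibition:
- compound 1 `CC1(C)[C@H]2CC[C@]1(C)N(Cc1cn(-c3ccc(O)cc3)nn1)C(=O)C2`: 330 nM
- compound 2 `CC1(C)[C@H]2CC[C@]1(C)N(Cc1cn(-c3ccc(Br)cc3)nn1)C(=O)C2`: 450 nM

Within the data shown here, at 450 nM, compound 2 cannot be told apart from the only other measured compound, since the gap between them is a 1.4-fold higher number from compound 1 to compound 2 (0.13 log units; within the scatter). The next compound, compound 3 `CC1(C)[C@H]2CC[C@]1(C)N(Cc1cn(-c3ccc(Cl)cc3)nn1)C(=O)C2`, keeps the shared core and changes one substituent: chloro in place of bromo on an aromatic carbon. This puts chloro in place of bromo on an aromatic carbon, para to a large group, turning 4-bromophenyl into 4-chlorophenyl.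

Among the measured compounds shown here, only one measured step bears on this change. It altered the same ring carbon, replacing hydroxy with bromo, and it stayed small: a 1.4-fold higher number from compound 1 to compound 2 (0.13 log units; within the scatter). One step is thin evidence, but it gives no reason to expect a large shift in this assay here. The expected change is a 1.1-fold lower number from compound 2 to compound 3 (0.05 log units; within the scatter), which means none beyond the scatter.

For compound 3 the estimated value is 400 nM, with an expected range of 190 nM to 850 nM.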

Compound 3, half-maximal inhibitory concentration: 410 nM
For compound 3 the middle estimate is 1.0-fold (0.01 log units) below the measured one; measured number inside the range.
By their numbers in this assay, from the lowest: compounds 1, 3 and 2 (each within the scatter of the next).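

In this assay, exchanging one halogen for the other on this aromatic carbon, para to a large group, gives a 1.1-fold lower number from compound 2 to compound 3 (0.04 log units; within the scatter) and so leaves no difference that can be told from the scatter. Going from hydroxy to chloro at the same carbon gives a 1.2-fold higher number from compound 1 to compound 3 (0.09 log units; within the scatter), which is also within the scatter, so hydroxy, bromo and chloro have now all been placed here with no separation among compounds 1, 2 and 3. Nothing measured here offers a reason for this flat picture.

Going by these compounds, it remains open whether a group of another kind at this carbon, such as an amine, a carboxylic acid or a longer chain, would move the number beyond the scatter. On these data alone, it is also open whether changes elsewhere on the shared core would do so.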